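Phenyl for Methyl on Two Related Cores

A few compounds are considered here, and "the series" means these few. Any claim that something is new, unique, unknown or untested is made for them only; others in the source may bear on it.

Measured compounds:
Compound 1 `Cc1c[se]c(NNC(=O)c2ccc(Cl)cc2)n1`: in a functional assay on HepG2 cells (Homo sapiens) for cytotoxicity, read by XTT assay, with a stated time of 72 h (on this read-out higher numbers stand for weaker inhibition and lower numbers for stronger inhibition), compound 1 reaches only the limit of > 79400 nM.
Compound 2 `O=C(NNc1nc(-c2ccccc2)c[se]1)c1ccc(Cl)cc1`: in this assay compound 2 gives 62900 nM.
Compound 3 `CC(=O)N(C(=O)c1ccc(Cl)cc1)N(C(C)=O)c1nc(C)c[se]1`: in this assay compound 3 reaches only the limit of > 62700 nM.

Compound 1 and compound 2 share one core and differ in a single place: phenyl in place of methyl on an aromatic carbon. The value of compound 1 is a limit. The step is therefore given only as a floor: an at least 1.2-fold lower number from compound 1 to compound 2 (0.10 log units; that floor lies within the scatter). Compound 3 and compound 1 differ in more than one place, and the difference between the two cores is not broken down here. Compound 3 also sits at a limit in this assay, and it is one of two such limits among the three values the limit of > 62700 nM in this assay, at which 1 of the 3 values shown sits (the limit of > 79400 nM in this assay, at which 1 of the 3 values shown sits).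

Compound 4 `CC(=O)N(C(=O)c1ccc(Cl)cc1)N(C(C)=O)c1nc(-c2ccccc2)c[se]1` is not yet measured. It stands to compound 3 exactly as compound 2 stands to compound 1, the same change at the same kind of place: phenyl in place of methyl on an aromatic carbon. Among the measured compounds shown here, the only guide is the measured step from compound 1 to compound 2, which did not move the number beyond the usual scatter.

On that basis the step to compound 4 is expected to be small, a step that the limit leaves unreadable from compound 3 to compound 4, resting on an at least 1.2-fold lower number from compound 1 to compound 2 (0.10 log units; that floor lies within the scatter). Compound 4 is therefore estimated at 70000 nM, with a plausible range from 30000 nM to 200000 nM, and a good chance that the assay again reports only a limit.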

Compound 4, half-maximal inhibitory concentration: > 54200 nM
Compound 4: no number, only a limit; the forecaster's own chance of this, stated with the estimate: 65%; the middle value does not contradict the limit.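

In this assay compound 4 reaches only the limit of > 54200 nM and no exact number. Compound 3 likewise reaches only the limit of > 62700 nM in this read-out, and the step between compound 3 and compound 4 cannot be read. The compounds shown leave open whether phenyl in place of methyl on an aromatic carbon changes the number at all on this core.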